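This account rests on a few compounds, and the source may have more. Where it says the series, first, only, none or still open, it means among the compounds named here.

Measured in an ADME assay on Huh7.5.1 cells (Homo sapiens) for cytotoxicity, read by WST assay, with a stated time of 48 h; on this read-out higher numbers stand for lower toxicity in this test and lower numbers for higher toxicity in this test:
- Compound 1 `CN=S(=O)(c1ccc(Cc2ccc(-c3[nH]c4cccc(F)c4c(=O)c3C)cc2)cc1)C(F)(F)F`: > 10000 nM
- Compound 2 `Cc1c(-c2ccc(Oc3ccc(N4CCCC4)cc3)c(F)c2)[nH]c2cccc(F)c2c1=O`: > 10000 nM

Compound 2 has no exact number: its entry of > 10000 nM is a limit of the assay. Compound 1 gives no exact number either, so the data so far amount to the limit of > 10000 nM in this assay, at which 2 of the 2 values shown sit. Compound 3 `Cc1c(-c2ccc(Oc3ccc(N4CCNCC4)cc3)c(F)c2)[nH]c2cccc(F)c2c1=O` has piperazin-1-yl in place of pyrrolidin-1-yl on an aromatic carbon, para to a large group (piperazin-1-yl in place of pyrrolidin-1-yl on an aromatic carbon). For the measured compounds named here, no measured pair shows what a change of this kind does in this assay, so the expectation is for no step beyond the scatter, in either direction. Going by the values given here, the only close reference is compound 2, with its limit of > 10000 nM. The expected step, a number no higher from compound 2 to compound 3 (the limit leaves the size open), is only a rough estimate. The estimate for compound 3 is 10000 nM, with an expected range of 4000 nM to 25000 nM.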

Compound 3, half-maximal cytotoxic concentration: > 10000 nM
Compound 3: a limit, no number (the forecaster's own chance of this, stated with the estimate: 60%); the middle value sits exactly at the limit.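

Compound 2 and compound 3 each give only a limit and no number in this assay, so no step can be read between them. The compounds shown leave open whether piperazin-1-yl in place of pyrrolidin-1-yl changes this read-out at all, and all of them remain unseparated: the limit of > 10000 nM in this assay, at which 3 of the 3 values shown sit.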